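This account rests on a few compounds, and the source may have more. Where it says the series, first, only, none or still open, it means among the compounds named here.

Measured so far in an ADME assay for solubility; on this read-out higher numbers stand for higher solubility and lower numbers for lower solubility:
- Compound 1 `CCOc1cc(NC(=O)C2(NC(=O)c3ccc4c(C5CCCC5)c(-c5ncc(Cl)cn5)n(C)c4c3)CCC2)ccc1/C=C/C(=O)OCCOCCOC` gives the limit < 60000 ug/mL
- Compound 2 `CCOc1cc(NC(=O)C2(NC(=O)c3ccc4c(C5CCCC5)c(-c5ncc(Cl)cn5)n(C)c4c3)CCC2)ccc1/C=C/C(=O)OCC(N)=O` gives the limit < 200000 ug/mL
- Compound 3 `CCOc1cc(NC(=O)C2(NC(=O)c3ccc4c(C5CCCC5)c(-c5ncc(Cl)cn5)n(C)c4c3)CCC2)ccc1/C=C/C(=O)OCC(=O)N(C)C(C)C` gives the limit < 200000 ug/mL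

Compound 3 is known only by a limit of this assay, which is < 200000 ug/mL, and not by a true number. This is the limit of < 200000 ug/mL in this assay, at which 2 of the 3 values shown sit, and none of the three compounds has a true number to compare it with.

Compound 4 `CCOc1cc(NC(=O)C2(NC(=O)c3ccc4c(C5CCCC5)c(-c5ncc(Cl)cn5)n(C)c4c3)CCC2)ccc1/C=C/C(=O)OCC(=O)N1CCOCC1` differs from compound 3 in one group on a carbonyl carbon, with morpholin-4-yl in place of isopropyl(methyl)amino on a carbonyl carbon. The entering group brings a six-membered non-aromatic ring and a hydrogen-bond acceptor.

The measured change closest to this one, made on the same carbonyl carbon, is a step that the two limits leave unreadable from compound 2 to compound 3. The other two measured changes, a step that the two limits leave unreadable from compound 1 to compound 2 and a step that the two limits leave unreadable from compound 1 to compound 3, reveal no more. No size or direction can therefore be carried over, and no step beyond the usual scatter is expected.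

The only anchor for this expectation is compound 3 with its limit < 200000 ug/mL, and another limit is the likeliest report. The estimated change is a step that the limit leaves unreadable from compound 3 to compound 4 in this assay. For compound 4 the estimated value is 120000 ug/mL, with an expected range from 30000 ug/mL to 200000 ug/mL.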

Compound 4, solubility: < 15000 ug/mL
Compound 4 gave a limit, no number; the forecaster's own chance of this, stated with the estimate: 75%; middle value at least 8.0-fold (0.90 log units) from the limit.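

In this assay compound 4 gives < 15000 ug/mL, which is a limit and not a number. Within the data shown here, compound 1, compound 2 and compound 3 are also known only by limits, and no step from any of them to compound 4 can be read. Going by these compounds, the true numbers for these four compounds, and whether they differ at all, remain open.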